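This account rests on a few compounds, and the source may have more. Where it says the series, first, only, none or still open, it means among the compounds named here.

Of the compounds shown here, two of the same core have been tested so far. Compound 1 `CCCCCCCCCCCCCCNC(=O)[C@H](CO)/N=C/c1ccccc1OC` gives 12500 nM in a functional assay on cells (Homo sapiens) for cytotoxicity, read by MTT assay, with a stated time of 24 h; on this read-out higher numbers stand for weaker inhibition and lower numbers for stronger inhibition. Compound 2 `CCCCCCCCCCCCCCNC(=O)[C@H](CO)/N=C/c1ccccc1C` gives 87700 nM in this assay, the higher of the two numbers: a 7.0-fold higher number from compound 1 to compound 2 (0.85 log units; beyond the scatter). Compound 3 `CCCCCCCCCCCCCCNC(=O)[C@H](CO)/N=C/c1cccc(OC)c1` has not yet been measured in this assay. It differs from compound 2 in one place: 3-methoxyphenyl in place of 2-methylphenyl on a carbon with a double bond to nitrogen. Within the data shown here, only one measured step bears on this change, and only in part: the step from compound 1 to compound 2, which brought methyl in place of methoxy and raised the number modestly, a 7.0-fold higher number from compound 1 to compound 2 (0.85 log units; beyond the scatter). Among the measured compounds shown here, compound 3 brings a methoxy group back, but on a different carbon of the ring, and no measured pair shows what that shift alone does. He therefore expects a lower number than compound 2, of uncertain size: a 2.9-fold lower number from compound 2 to compound 3 (0.47 log units; beyond the scatter). For compound 3 his estimate in this assay is 30000 nM, within a range from 8000 nM to 100000 nM.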

Compound 3, half-maximal inhibitory concentration: 31300 nM
Compound 3: middle estimate off by 1.0-fold (0.02 log units), on the low side; the measured number falls inside the stated range.
By their numbers in this assay, from the lowest: compound 1; then compound 3; then compound 2.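

In this assay, the new pair gives a 2.5-fold higher number from compound 1 to compound 3 (0.40 log units; beyond the scatter) for a move of the methoxy group alone, which the earlier pair could not separate from a change of group. The number still stays under that of the methyl compound, with a 2.8-fold lower number from compound 2 to compound 3 (0.45 log units; beyond the scatter) so that both methoxy compounds lie on the lower side of compound 2 and the place of the methoxy group on the ring matters as well. Nothing given here accounts for these differences.

On these data alone, what the methyl group of compound 2 would do under the same shift remains open. So does whether an amine or a carboxylic acid on the ring would bring the number below that of compound 1.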